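The source may report more compounds than this note shows. Statements on the series, on what has been measured and on what is new or still open speak of the compounds shown alone.

Measured in a functional assay on COR-L23 cells (Homo sapiens) for antiproliferative activity, read by CellTiter-Glo, with a stated time of 4 days; a higher number here means a weaker inhibitor, a lower number a stronger inhibitor:
- compound 1 `CCC(=O)N[C@@H](C)c1ccc(NC(=O)[C@H]2C[C@@H]2c2cccnc2)cc1`: 22 nM
- compound 2 `C[C@H](NC(=O)c1ccccc1)c1ccc(NC(=O)[C@H]2C[C@@H]2c2cccnc2)cc1`: 8 nM

Compound 2, at 8 nM, has the lower number of the two and is the stronger inhibitor. Compound 3 `C[C@H](NC(=O)c1ccc(C#N)cc1)c1ccc(NC(=O)[C@H]2C[C@@H]2c2cccnc2)cc1` alters it in one place: cyano in place of hydrogen on an aromatic carbon. The benzoyl group thus becomes (4-cyanophenyl)carbonyl. Among the compounds with values here, the only measured step nearby, phenyl in place of ethyl on a carbonyl carbon, was modest: a 2.8-fold lower number from compound 1 to compound 2 (0.44 log units; beyond the scatter). It involves no cyano group, so it gives only weak guidance, and no shift beyond the scatter is expected in this assay. The expected change is a 1.1-fold lower number from compound 2 to compound 3 (0.06 log units; within the scatter). Compound 3 is estimated at 7 nM, with an expected range of 2.5 nM to 20 nM.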

Compound 3, half-maximal inhibitory concentration: 19 nM
Beside the measured number, compound 3's estimate is 2.7-fold (0.43 log units) below it, and the stated range covers the measured number.
By their numbers in this assay, from the lowest: compound 2; then compounds 3 and 1 (each within the scatter of the next).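

In this assay, this place on the benzoyl ring, para to a large group, responds to substitution: cyano on that aromatic carbon gives a 2.4-fold higher number from compound 2 to compound 3 (0.38 log units; beyond the scatter), so hydrogen is the better of the two here. With cyano present, the advantage of the aromatic ring over ethyl disappears, as 4-cyanophenyl in place of ethyl gives only a 1.2-fold lower number from compound 1 to compound 3 (0.06 log units; within the scatter), a step within the scatter. No measurement here explains this shift. Going by these compounds, whether an amine or a fluorine atom at this same carbon would behave like cyano or like hydrogen remains open.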